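Changing one side group on compound 1

The compounds below may be only part of what the source reports. "The series", "measured", "known", "first", "only" and "open" are said of these compounds alone.

Within the data shown here, compound 1 (`Cc1cc(OCc2ccc(F)cc2F)c(Br)c(=O)n1Cc1ccc(C(=O)N(C)C)cc1`) gives 51% in an ADME assay on microsomes from liver (Rattus norvegicus) for metabolic stability, read by LC-MS, with a stated time of 45 min, tested at 2 uM (a higher number here means that more of the compound is left, a lower number that less of the compound is left), and stands highest of the two compounds measured so far. Compound 2 (`O=c1c(Br)c(OCc2ccc(F)cc2F)ccn1Cc1cccc(F)c1`) gives 16% in this assay and lies below compound 1 by a gap beyond the usual scatter. These two compounds differ in more than one place, so their gap cannot be tied to any single group.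

Compound 3 (`Cc1cc(OCc2ccc(F)cc2F)c(Br)c(=O)n1Cc1ccc(CNC(=O)CO)cc1`) has not yet been measured. It carries (((hydroxymethyl)carbonyl)amino)methyl in place of dimethylcarbamoyl on an aromatic carbon and keeps the rest of compound 1 unchanged. Among the measured compounds shown here, no measured pair shows the effect of a swap like this one, so the only firm anchor is compound 1 at 51% in this assay itself. The step of a number 3 percentage points lower from compound 1 to compound 3 (within the scatter) is therefore expected to stay within the scatter, with no clear direction. In this assay the estimate for compound 3 is 48% with an expected range from 28% to 70% around that value.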

Compound 3, percent of the compound remaining: 82%
The estimate for compound 3 lay 34 percentage points below the measured number, outside the stated range (above it).
By their numbers in this assay, from the lowest: compound 2; then compound 1; then compound 3.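

Among these compounds, this pair gives the first clean reading of a single change, since compound 1 and compound 3 differ in one place only, on an aromatic carbon para to a large group. In this assay, swapping dimethylcarbamoyl for (((hydroxymethyl)carbonyl)amino)methyl gives a number 31 percentage points higher from compound 1 to compound 3 (beyond the scatter), so the side group at this position alone can shift how much compound is left, and the shared core does not fix that number. The swap changes several things at once, including 2 hydrogen-bond donors where dimethylcarbamoyl has 0, and nothing available here explains why the number rose.

Going by these compounds, it remains open which part of the new group carries the step: the terminal hydroxyl, the amide hydrogen or the extra carbon that links the amide to the aromatic ring. Whether a simple aminomethyl, a carboxylic acid or a longer chain with a hydroxyl at its end would behave the same way at this position is also unsettled, as is whether the same swap would give a similar step on the core of compound 2.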